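The source may report more compounds than this note shows. Statements on the series, on what has been measured and on what is new or still open speak of the compounds shown alone.

Working notes on the series

The series rests on one shared core carrying two hydroxyphenyl groups and one further aryl group. Compound 1 `Oc1ccc(-c2cc(-c3ccccc3F)cc(-c3cccc(O)c3)n2)cc1` gives 14300 nM in a functional assay on HeLa cells (Homo sapiens) for inhibition; on this read-out higher numbers stand for weaker inhibition and lower numbers for stronger inhibition. Compound 3 `Oc1ccc(-c2cc(-c3ccccc3C(F)(F)F)cc(-c3cccc(O)c3)n2)cc1` carries a trifluoromethyl in place of the fluoro of compound 1; in this assay compound 3 gives 17400 nM, and the step of a 1.2-fold higher number from compound 1 to compound 3 (0.09 log units; within the scatter) stays inside the scatter, so the two read as the same. Compound 2 `Oc1ccc(-c2cc(-c3ccccc3F)cc(-c3ccc(O)cc3)n2)cc1` differs from compound 1 by 4-hydroxyphenyl in place of 3-hydroxyphenyl on an aromatic carbon. For compound 2 this assay reports only a limit, > 50000 nM, not a number. That limit is the limit of > 50000 nM in this assay, at which 1 of the 3 values shown sits. The step of an at least 3.4-fold higher number from compound 1 to compound 2 (0.54 log units; beyond the scatter) is accordingly a floor on the loss, not its full size.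

Compound 4 `Oc1ccc(-c2cc(-c3ccccc3C(F)(F)F)cc(-c3ccc(O)cc3)n2)cc1` is not yet measured. It stands to compound 3 as compound 2 stands to compound 1: 4-hydroxyphenyl in place of 3-hydroxyphenyl on an aromatic carbon. The two cores differ by trifluoromethyl in place of fluoro on an aromatic carbon. It is the same kind of change, not the same: around the place, the entering group is meta to a 2-(trifluoromethyl)phenyl group rather than meta to a 2-fluorophenyl group. For compound 4 the step of a 4.0-fold higher number from compound 3 to compound 4 (0.60 log units; beyond the scatter) is expected, resting on the step of an at least 3.4-fold higher number from compound 1 to compound 2 (0.54 log units; beyond the scatter) seen from compound 1 and on the starting value of compound 3 at 17400 nM. Compound 4 is thus estimated at 70000 nM, between 35000 nM and 150000 nM, with a real chance that this assay again returns only a limit.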

Compound 4, half-maximal inhibitory concentration: > 50000 nM
Compound 4 ended at the assay's limit; the forecaster's own chance of this, stated with the estimate: 70%; the middle value does not contradict the limit.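

The change to 4-hydroxyphenyl in place of 3-hydroxyphenyl costs inhibition on the trifluoromethyl core as well, with the step of an at least 2.8-fold higher number from compound 3 to compound 4 (0.45 log units; beyond the scatter) again only a floor on the loss, so across these two pairs the direction of the change carries from one core to the other: the same change on two cores in this assay, an at least 3.4-fold higher number (0.54 log units; beyond the scatter) from compound 1 to compound 2 and an at least 2.8-fold higher number (0.45 log units; beyond the scatter) from compound 3 to compound 4; the limit leaves it open whether they differ

Two pairs are a narrow base, and they do not show that the size of the loss carries over, as neither 4-hydroxyphenyl compound gives a number in this assay: the limit of > 50000 nM in this assay, at which 2 of the 4 values shown sit.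

The step from compound 2 to compound 4 cannot be read, so nothing can be said about trifluoromethyl in place of fluoro on the core that carries two 4-hydroxyphenyl groups.

The compounds shown leave open what happens at the changed place when the hydroxyl of the hydroxyphenyl group gives way to a methoxy, an amine or a carboxylic acid, and whether any of these would give a readable number in this assay. They also leave open whether a chloro or a nitrile in place of the fluoro would separate from compound 1 and compound 3, which read as the same.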